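The source may report more compounds than this note shows. Statements on the series, on what has been measured and on what is new or still open speak of the compounds shown alone.

Measured compounds:
compound 1 `CC(C)C(=O)N1CCC(CNc2ccc(S(=O)(=O)NC(=O)c3ccc(N4CCN(CC5=C(c6ccc(C(F)(F)F)cc6)CC(C)(C)CC5)CC4)cc3Oc3cnc4[nH]ccc4c3)cc2[N+](=O)[O-])CC1`, 2.4 nM in an assay on isolated protein for displacement of a labelled ligand from Apoptosis regulator Bcl-2 (Homo sapiens), with a stated time of 15 min; a higher number here means a weaker inhibitor, a lower number a stronger inhibitor
compound 2 `CC1(C)CCC(CN2CCN(c3ccc(C(=O)NS(=O)(=O)c4ccc(NC5CCOC5)c([N+](=O)[O-])c4)c(Oc4cnc5[nH]ccc5c4)c3)CC2)=C(c2ccc(C(F)(F)F)cc2)C1`, 1.9 nM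

Among the measured compounds shown here, compound 2 is one of two compounds measured here, and its value sits within the scatter of that of compound 1; the single measured step of a 1.3-fold lower number from compound 1 to compound 2 (0.10 log units; within the scatter) shows that swapping the group on the nitrogen attached to the aromatic ring leaves the result essentially unchanged. Compound 3 `CC1(C)CCC(CN2CCN(c3ccc(C(=O)NS(=O)(=O)c4ccc(OCC5CCCOC5)c([N+](=O)[O-])c4)c(Oc4cnc5[nH]ccc5c4)c3)CC2)=C(c2ccc(C(F)(F)F)cc2)C1` takes a further step from compound 2: a group of 8 heavy atoms (6 carbon, 2 oxygen; one six-membered non-aromatic ring with 1 hetero atom) in place of a group of 6 heavy atoms (4 carbon, 1 nitrogen, 1 oxygen; one five-membered non-aromatic ring with 1 hetero atom), on an aromatic carbon. Here the nitrogen that carried the hydrogen-bond donor is itself replaced by an oxygen link, so the change goes beyond what the measured step covers. From the compounds shown here alone, that step gives no ground to expect a large shift, yet the loss of the donor is untested, so compound 3 is expected to give a somewhat weaker result, with the step of a 2.4-fold higher number from compound 2 to compound 3 (0.37 log units; beyond the scatter) modest. The estimate for compound 3 is 4.5 nM, in a range from 1.5 nM to 15 nM.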

Compound 3, half-maximal inhibitory concentration: 3 nM
Estimate against measurement, compound 3: 1.5-fold (0.18 log units) above; the range from low to high includes it.
By their numbers in this assay, from the lowest: compounds 2, 1 and 3 (each within the scatter of the next).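

In this assay, the step of a 1.6-fold higher number from compound 2 to compound 3 (0.20 log units; within the scatter) shows that this place, on an aromatic carbon ortho to a nitro group, accepts more than a change of the group carried by the nitrogen. The (oxolan-3-yl)amino group, with 1 hydrogen-bond donor, gives way to a larger group with a six-membered ring and 0 hydrogen-bond donors, and the values stay within the scatter, so in this pair the donor is not needed for a low nanomolar value. No measurement here explains this tolerance.

Ring size and the loss of the nitrogen change together in this step, so their separate contributions remain unknown. From the compounds shown here alone, it also remains open whether a carboxylic acid, a primary amine or a long open carbon chain at this place would hold the value as well.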